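Efficacy series: aryl swap on the ring nitrogen

A few compounds are considered here, and "the series" means these few. Any claim that something is new, unique, unknown or untested is made for them only; others in the source may bear on it.

Measured so far in a functional assay on CHO-K1 cells with Glucose-dependent insulinotropic receptor (Homo sapiens) as the target, read by a luciferase reporter, with a stated time of 5 h; on this read-out higher numbers stand for larger maximal responses and lower numbers for smaller maximal responses:
- compound 1 `CC(C)(C)COC(=O)N1CCC(Oc2ncnc3c2CCN3c2ccc(S(C)(=O)=O)cc2F)CC1` gives 80%
- compound 2 `CC(C)c1noc(N2CCC(Oc3ncnc4c3CCN4c3ccc(S(C)(=O)=O)cc3F)CC2)n1` gives 124%
- compound 3 `CC(C)OC(=O)N1CCC(Oc2ncnc3c2CCN3c2ccc(S(C)(=O)=O)cn2)CC1` gives 111%

Compound 3 stands second highest of the three. Compound 2 lies beyond the scatter above it, compound 1 beyond the scatter below it. For the measured compounds named here, the one single-point step so far is a number 44 percentage points higher from compound 1 to compound 2 (beyond the scatter), which sits at the carbamate end of the shared core and not where compound 4 changes.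

Compound 4 `CSc1ccc(N2CCc3c(OC4CCN(C(=O)OC(C)C)CC4)ncnc32)cc1F` differs from compound 3 at the other end: a group of 9 heavy atoms (7 carbon, 1 fluorine, 1 sulfur; one six-membered aromatic ring of carbon only) in place of a group of 10 heavy atoms (6 carbon, 1 nitrogen, 2 oxygen, 1 sulfur; one six-membered aromatic ring with 1 hetero atom), on a nitrogen on an aromatic ring in a ring. Going by the values given here, no measured pair changes this position; compounds 1 and 2 both carry a fluorophenyl bearing a methylsulfonyl, compound 3 a methylsulfonyl pyridinyl, and the carbamate or oxadiazole varies alongside, so nothing isolates the effect of the aryl. The step from compound 1 to compound 2 therefore does not bear on this change, and no direction can be drawn from the shown numbers.

Among the compounds with values here, with no direct precedent, the estimate for compound 4 is a maximal response near that of compound 3, with a wide range: 100%, between 70% and 130%. The expected step is a number 11 percentage points lower from compound 3 to compound 4 (beyond the scatter), within the scatter.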

Compound 4, largest response reached (reported as percent of maximum), in percent of the reference or control that the assay uses: 121%
Beside the measured number, compound 4's estimate is 21 percentage points below it; the range from low to high includes it.
By their numbers in this assay, from the lowest: compound 1; then compounds 3, 4 and 2 (each within the scatter of the next, the first and the last beyond it).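

Working notes on the aryl position: in this assay, the first pair to change only the group on a nitrogen on an aromatic ring in a ring gives a number 10 percentage points higher from compound 3 to compound 4 (within the scatter), so the maximal response does not separate these two groups. With the isopropoxycarbonyl end held constant, the 5-(methylsulfonyl)pyridin-2-yl group can therefore give way to an all-carbon aromatic ring bearing fluorine and a sulfur group, with no oxygen and no ring nitrogen, without a step beyond the scatter. No supporting measurement accounts for this outcome, and the ring nitrogen, the fluorine and the state of the sulfur all differ within this single step, so their separate contributions cannot be assigned.

Still open, as far as these compounds go, is how this position responds to other substituents on the aromatic ring, such as a nitrile, an amide or a carboxylic acid in place of the sulfur group. Also open, from the compounds shown here alone, is whether the same swap gives a comparable result when the isopropoxycarbonyl is replaced by neopentyloxycarbonyl or 3-isopropyl-1,2,4-oxadiazol-5-yl on the ring amine nitrogen.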